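Sulfamoylphenyl for nitrophenyl on the sulfoxide anilide

This account rests on a few compounds, and the source may have more. Where it says the series, first, only, none or still open, it means among the compounds named here.

The series shares the core of compound 1 `COc1cc2nc(SCC(=O)Nc3ccc(S(N)(=O)=O)cc3)nc(Nc3c(Cl)cc(/C=C/C#N)cc3Cl)c2cc1OC` and varies the anilide. In an ADME assay on MT4 cells (Homo sapiens) for cytotoxicity, read by MTT assay, with a stated time of 5 days (a higher number here means that more compound is tolerated, a lower number that less compound is tolerated), compound 1 gives 116000 nM. Compound 2 `COc1cc2nc(SCC(=O)Nc3ccc(C(F)(F)F)cc3)nc(Nc3c(Cl)cc(/C=C/C#N)cc3Cl)c2cc1OC` carries trifluoromethyl in place of sulfamoyl on an aromatic carbon; in this assay compound 2 gives > 197000 nM, a limit of the assay rather than a number (the limit of > 197000 nM in this assay, at which 1 of the 3 values shown sits). That step is an at least 1.6-fold higher number from compound 1 to compound 2 (0.23 log units; that floor lies within the scatter). Compound 3 `COc1cc2nc([S+]([O-])CC(=O)Nc3ccccc3[N+](=O)[O-])nc(Nc3c(Cl)cc(/C=C/C#N)cc3Cl)c2cc1OC` bears the sulfoxide and a 2-nitrophenyl on the amide-type nitrogen. In this assay compound 3 gives > 199000 nM, again only a limit of the assay and not a number (the limit of > 199000 nM in this assay, at which 1 of the 3 values shown sits). Compound 3 therefore stands at the ceiling of what was tested, alongside compound 2.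

Among the compounds with values here, compound 4 `COc1cc2nc([S+]([O-])CC(=O)Nc3cccc(S(N)(=O)=O)c3)nc(Nc3c(Cl)cc(/C=C/C#N)cc3Cl)c2cc1OC` is the next member. 3-sulfamoylphenyl in place of 2-nitrophenyl on an amide-type nitrogen The one measured step that bears on a sulfamoyl group, from compound 1 to compound 2, stayed within the scatter, and the single sulfamoyl-bearing compound that returned a number, compound 1, sits at 116000 nM. Within the data shown here, no step touching the sulfoxide is available. The step from compound 3 to compound 4 is therefore expected to be an at least 1.5-fold lower number from compound 3 to compound 4 (0.18 log units; that floor lies within the scatter), a move toward a measurable number rather than a shift beyond the scatter. For compound 4 the expected value in this assay is 130000 nM, with a range from 55000 nM to 200000 nM.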

Compound 4, half-maximal cytotoxic concentration: 67800 nM
Compound 4: the middle estimate sits 1.9-fold (0.28 log units) above what was measured; measured number inside the range.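

In this assay, 3-sulfamoylphenyl in place of 2-nitrophenyl on the amide-type nitrogen gives an at least 2.9-fold lower number from compound 3 to compound 4 (0.46 log units; beyond the scatter). Unlike the trifluoromethyl-for-sulfamoyl step among the earlier compounds, which stayed within the scatter, this change to the anilide has an effect that can be told apart from the scatter, and it does so on the sulfoxide. The size of the step remains a floor, since compound 3 stands only at a limit of the assay and not at a number: the limit of > 199000 nM in this assay, at which 1 of the 4 values shown sits.

The two compounds here that return a number, compound 1 and compound 4, both carry a sulfamoyl group, while compound 2 and compound 3, which carry none, stand at limits, a pattern that rests on these four compounds alone.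

The step swaps the group and changes its place on the ring together, and the compounds shown do not separate the two. As far as these compounds go, whether an amine or a carboxylic acid on the phenyl ring would bring the same fall as the sulfamoyl group also stays open, as does any separate contribution of the sulfoxide.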